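This account rests on a few compounds, and the source may have more. Where it says the series, first, only, none or still open, it means among the compounds named here.

Of the compounds shown here, two of this set have been measured in a functional assay on MCF7 cells (Homo sapiens) for inhibition, read by MTT assay, with a stated time of 48 h; on this read-out higher numbers stand for weaker inhibition and lower numbers for stronger inhibition. Compound 1, `O=C(N/N=C/c1c(-c2cc3ccccc3oc2=O)[nH]c2ccccc12)c1ccccc1Cl`, gives 164000 nM in this assay. Compound 2, `O=C(N/N=C/c1c(-c2cc3ccc(Br)cc3oc2=O)[nH]c2ccccc12)c1ccccc1`, gives 9100 nM in this assay, which is the lowest of the two numbers; the gap to compound 1 lies well beyond the scatter, but the two structures differ in two places, so the numbers alone do not say which change matters. Compound 3, `O=C(N/N=C/c1c(-c2cc3ccc(Br)cc3oc2=O)[nH]c2ccccc12)c1ccccc1Cl`, is not yet measured. It differs from compound 2 in one place: chloro in place of hydrogen on an aromatic carbon. Among the measured compounds shown here, no measured pair shows the effect of this change alone. The expected step from compound 2 to compound 3 in this assay is a 1.5-fold higher number from compound 2 to compound 3 (0.19 log units; within the scatter), a modest shift toward weaker inhibition that may not exceed the scatter. Compound 3 is therefore estimated at 14000 nM in this assay, with a likely range from 3500 nM to 60000 nM.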

Compound 3, half-maximal inhibitory concentration: > 192000 nM
Compound 3: only a limit was reported; the forecaster's own chance of this, stated with the estimate: 5%; middle value at least 13-fold (1.13 log units) away from the limit.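

With the bromo group kept in place, the step from phenyl to 2-chlorophenyl can now be read on its own in this assay: an at least 21-fold higher number from compound 2 to compound 3 (1.32 log units; beyond the scatter), a large move toward weaker inhibition from a single added atom ortho to a large group. Compound 3 gives only a limit and not a number, so the full size of that step stays unknown: the limit of > 192000 nM in this assay, at which 1 of the 3 values shown sits.

Among the compounds shown here, the bromo change can also be read for the first time, with chloro present: an at least 1.1-fold higher number from compound 1 to compound 3 (0.06 log units; that floor lies within the scatter), and this floor alone shows no change beyond the scatter.

Whether this loss belongs to chloro itself or to any group at this place stays open, since a fluoro, a methoxy or an amine there is not among the compounds shown. As far as these compounds go, the effect of bromo on the plain benzoyl series also remains open.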